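Arylpiperazine series: thiol for bromo-cyano exchange

A few compounds are considered here, and "the series" means these few. Any claim that something is new, unique, unknown or untested is made for them only; others in the source may bear on it.

Among the measured compounds shown here, compound 2 `Cn1c(=O)cnn(CCCCN2CCN(c3c(Br)cccc3C#N)CC2)c1=O` is one of two compounds measured so far in an assay for displacement of a labelled ligand from Adrenergic receptor alpha-1 (Homo sapiens); on this read-out lower numbers stand for stronger inhibition and higher numbers for weaker inhibition. In this assay compound 2 gives 450 nM, the higher of the two numbers. Compound 1 `COc1ccc(N2CCN(CCCCn3ncc(=O)n(C)c3=O)CC2)c(C#N)c1` gives 380 nM in this assay; the two numbers lie within the scatter of each other, so compound 2 is not separated from compound 1 on this read-out. Compound 3 `Cn1c(=O)cnn(CCCCN2CCN(c3ccccc3S)CC2)c1=O` is not yet measured. The change from compound 2 to compound 3 is 2-sulfanylphenyl in place of 2-bromo-6-cyanophenyl on an amine nitrogen in a ring. For the measured compounds named here, no step between measured compounds isolates this change, and the two measured compounds differ in their groups on the ring nitrogen without a comparable exchange. The step of a 1.4-fold higher number from compound 2 to compound 3 (0.16 log units; within the scatter) is therefore expected to be small, a modest move toward a higher number, with a wide range around it. For compound 3 an inhibition constant of 650 nM is estimated, expected to fall between 160 nM and 2600 nM.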

Compound 3, inhibition constant: > 10000 nM
Compound 3 ended at the assay's limit; the forecaster's own chance of this, stated with the estimate: 5%; middle value at least 15-fold (1.18 log units) from the limit.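

In this assay, the exchange of 2-bromo-6-cyanophenyl for 2-sulfanylphenyl on the amine nitrogen gives an at least 22-fold higher number from compound 2 to compound 3 (1.34 log units; beyond the scatter), so the step is large. The value for compound 3 is a limit of the assay and not a number: the limit of > 10000 nM in this assay, at which 1 of the 3 values shown sits.

The earlier pair gave no sign of this sensitivity, since compound 1 at 380 nM and compound 2 at 450 nM lie within the scatter of each other despite carrying different groups at this position; compound 3 shows that the group here can decide the read-out.

The step removes bromo and nitrile and adds sulfanyl in a single exchange, so the compounds shown cannot assign the change to any one of them. A 2-cyanophenyl, a 2-bromophenyl or an unsubstituted phenyl on the same nitrogen would separate these contributions.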